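This account rests on a few compounds, and the source may have more. Where it says the series, first, only, none or still open, it means among the compounds named here.

Measured so far:
- compound 1, `CN(C[C@H]1Cc2c(cccc2N2CCN(C3CC3)CC2)CN1)[C@H]1CCCc2cccnc21`: 15.5%
- compound 2, `c1cnc2c(c1)CCC[C@@H]2N(CC1CCCCC1)C[C@H]1Cc2c(cccc2N2CCNCC2)CN1`: 81.6%

Both compounds were tested in an ADME assay on microsomes from liver (Homo sapiens) for metabolic stability, read by LC-MS, with a stated time of 10 min; on this read-out lower numbers stand for a less stable compound and higher numbers for a more stable compound. Compound 1 gives 15.5%, the lower of the two numbers. Compound 2 gives 81.6%, a number well above that of compound 1, and the gap between them lies beyond the usual scatter of this kind of measurement. The two compounds differ in more than one place, so the two values alone do not tell which part of the structure matters.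

The next compound, compound 3, `CC(C)N1CCN(c2cccc3c2C[C@H](CN(C)[C@H]2CCCc4cccnc42)NC3)CC1`, is not yet measured. It is built from compound 1 by a single change: isopropyl in place of cyclopropyl on an amine nitrogen in a ring. The cyclopropyl leaves and an isopropyl enters on the same amine nitrogen in a ring, and both groups count the same number of heavy atoms. For the measured compounds named here, no measured pair shows this exact exchange, so there is nothing to lean on for its size. The expectation is a small step, a number 4.5 percentage points higher from compound 1 to compound 3 (within the scatter), not beyond the scatter. Compound 3 is therefore estimated at 20%, within a range from 8% to 40%.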

Compound 3, percent of the compound remaining: 56.6%
Beside the measured number, compound 3's estimate is 36.6 percentage points below it; measured number above the stated range.
By their numbers in this assay, from the lowest: compound 1; then compound 3; then compound 2.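

In this assay putting isopropyl in place of cyclopropyl on the amine nitrogen in the six-membered ring gives a number 41.1 percentage points higher from compound 1 to compound 3 (beyond the scatter) and so shows that this position matters for the read-out. The size of the step stands out. The exchange is a small one on paper: both groups count the same number of heavy atoms, all of them carbon, and what the count separates is that cyclopropyl holds a three-membered ring while isopropyl holds no ring. For the compounds shown here, this is also the first pair that differs in one place, so a change in the number can now be tied to one spot in the structure, although nothing measured here explains the step.

On these data alone, it remains open how other groups on the same nitrogen would behave, such as a small methyl, a tert-butyl or a larger cyclobutyl ring, and so whether the three-membered ring itself or something else about cyclopropyl sets the low number. As far as these compounds go, it also remains open whether the same exchange would give a step of similar size on a different core or with different groups elsewhere in the molecule.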